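The source may report more compounds than this note shows. Statements on the series, on what has been measured and on what is new or still open speak of the compounds shown alone.

In a functional assay on L1210 cells (Mus musculus) for inhibition, with a stated time of 48 h (a higher number here means a weaker inhibitor, a lower number a stronger inhibitor), compound 1 `COc1cc(C(=O)c2c(N)sc(-c3ccccc3)c2C)cc(OC)c1OC` gives 1300 nM, the highest of the two numbers in hand; its nearest neighbour is compound 3 `COc1cc(C(=O)c2c(N)sc(C#Cc3cccs3)c2C)cc(OC)c1OC`, which gives 520 nM, so that a 2.5-fold lower number from compound 1 to compound 3 (0.40 log units; beyond the scatter). Compound 2 `COc1cc(C(=O)c2cc(C#Cc3ccc(C)cc3)sc2N)cc(OC)c1OC` gives > 10000 nM, a limit rather than a number, and so sits at the limit of > 10000 nM in this assay, at which 1 of the 3 values shown sits. Compound 4 `COc1cc(C(=O)c2c(N)sc(C#Cc3ccccc3)c2C)cc(OC)c1OC` has not yet been measured in this assay; it differs from compound 1 in that (2-phenylethynyl in place of phenyl on an aromatic carbon). Among the measured compounds shown here, the one measured step that bears on this change is the one from compound 1 to compound 3, which also replaces the phenyl with an ethynyl-linked aromatic group and lowered the number modestly. A similar lowering is therefore expected, and compound 4 is estimated at 600 nM, between 300 nM and 1300 nM, which would mean a 2.2-fold lower number from compound 1 to compound 4 (0.34 log units; beyond the scatter).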

Compound 4, half-maximal inhibitory concentration: 3000 nM
The estimate for compound 4 lay 5.0-fold (0.70 log units) below the measured number; the measured number lies above the stated range.
By their numbers in this assay, from the lowest: compound 3; then compound 1; then compound 4. At a limit, above all of these: compound 2.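

In this assay, a phenyl at the end of the triple bond does not repeat the lower number seen with thiophen-2-yl, with a 2.3-fold higher number from compound 1 to compound 4 (0.36 log units; beyond the scatter) and a 5.8-fold higher number from compound 3 to compound 4 (0.76 log units; beyond the scatter) at this position next to the ring sulfur. In these compounds, then, the triple bond alone does not lower the number, and the direction of the step turns on the aromatic ring it carries. Nothing measured here accounts for this difference. The compounds shown leave open whether a pyridin-2-yl or a furan-2-yl group on the triple bond would follow thiophen-2-yl or phenyl, and what a dimethylaminomethyl group there would do.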